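Lengthening the fluorinated chain: compound 3 to compound 4

A few compounds are considered here, and "the series" means these few. Any claim that something is new, unique, unknown or untested is made for them only; others in the source may bear on it.

Measured compounds:
- compound 1, `[O-]/[N+](=C\c1cn(CCC(F)(F)C(F)(F)C(F)(F)C(F)(F)C(F)(F)C(F)(F)C(F)(F)C(F)(F)F)nn1)c1ccccc1`: > 100000 nM
- compound 2, `[O-]/[N+](=C\c1cn(CCC(F)(F)C(F)(F)C(F)(F)C(F)(F)C(F)(F)C(F)(F)C(F)(F)C(F)(F)F)nn1)Cc1ccccc1`: 9400 nM
- compound 3, `CC(C)(C)/[N+]([O-])=C/c1cn(CCC(F)(F)C(F)(F)C(F)(F)C(F)(F)C(F)(F)C(F)(F)F)nn1`: 9500 nM

In a functional assay on COLO 205 cells (Homo sapiens) for inhibition, read by MTT assay, with a stated time of 24 h (on this read-out higher numbers stand for weaker inhibition and lower numbers for stronger inhibition), compound 1 reaches only the limit of the assay, (the limit of > 100000 nM in this assay, at which 1 of the 3 values shown sits). In this assay compound 2 gives 9400 nM, and compound 3 gives 9500 nM, so the two numbers sit within the scatter of each other, with no order between them. Among the measured compounds shown here, the only step measured between neighbours, an at least 10-fold lower number from compound 1 to compound 2 (1.02 log units; beyond the scatter), concerns the group on the double-bonded nitrogen and not the fluorinated chain.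

Compound 4, `CC(C)(C)/[N+]([O-])=C/c1cn(CCC(F)(F)C(F)(F)C(F)(F)C(F)(F)C(F)(F)C(F)(F)C(F)(F)C(F)(F)F)nn1`, differs from compound 3 by 1,1,2,2,2-pentafluoroethyl in place of fluoro on a saturated chain carbon bound to two fluorine atoms and a saturated chain carbon. For the measured compounds named here, no measured step bears on this change, so the expected step of no change at the digits printed from compound 3 to compound 4 (within the scatter) is none beyond the scatter. Compound 4 is therefore estimated at 9500 nM in this assay, with a range from 3000 nM to 30000 nM.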

Compound 4, half-maximal inhibitory concentration: 28800 nM
Beside the measured number, compound 4's estimate is 3.0-fold (0.48 log units) below it, and the stated range covers the measured number.
By their numbers in this assay, from the lowest: compounds 2 and 3 (each within the scatter of the next); then compound 4. At a limit, above all of these: compound 1.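

In this assay, the fluorinated chain itself now moves the number: 1,1,2,2,2-pentafluoroethyl in place of fluoro on a saturated chain carbon bound to two fluorine atoms and a saturated chain carbon gives a 3.0-fold higher number from compound 3 to compound 4 (0.48 log units; beyond the scatter). With the chain held the same, the group on the double-bonded nitrogen also matters, so the closeness of compound 2 and compound 3 does not make benzyl and tert-butyl alike: tert-butyl in place of benzyl gives a 3.1-fold higher number from compound 2 to compound 4 (0.49 log units; beyond the scatter), and tert-butyl in place of phenyl gives an at least 3.4-fold lower number from compound 1 to compound 4 (0.54 log units; beyond the scatter). The value of compound 1 is a limit and not a number: the limit of > 100000 nM in this assay, at which 1 of the 4 values shown sits.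

The compounds shown leave open whether a still longer perfluoroalkyl chain, or a plain alkyl chain without fluorine, would continue this trend. They also leave open how benzyl behaves on the shorter fluorinated chain.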